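The compounds below may be only part of what the source reports. "The series", "measured", "known", "first", "only" and "open" are said of these compounds alone.

Measured compounds:
- compound 1 `Cc1cc(C(=O)O)ccc1CN1CCC[C@H](O[C@H](CO)c2ccnc(Cl)c2)[C@@H]1c1ccccc1` — > 200000 nM
- compound 2 `O=C(O)c1ccc(CN2CCC[C@H](O[C@H](CO)c3cc(Cl)cc(Cl)c3)[C@@H]2c2ccccc2)c(C2CC2)c1` — "nd" (no result reported)
- compound 3 `Cc1cc(C(=O)O)ccc1CN1CCC[C@H](O[C@H](CO)c2cc(Cl)cc(Cl)c2)[C@@H]1C1CCCCC1` — > 200000 nM

In an assay on isolated protein for activation of cGMP-dependent protein kinase 1 (Homo sapiens), read by ADP-Glo, with stated times of 30 min and 2 h (on this read-out higher numbers stand for an effect only at larger amounts of compound and lower numbers for an effect already at smaller amounts), compound 1 gives > 200000 nM, which is a limit of the assay and not a number. Compound 3 gives > 200000 nM in this assay, again a limit rather than a number. For compound 2 no result is reported in this assay, so its value is "nd" (no result reported). Compound 1 therefore stands where most of the shown values stand: the limit of > 200000 nM in this assay, at which 2 of the 3 values shown sit. Among the measured compounds shown here, no step between two measured compounds can be drawn from these data.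

Compound 4 `Cc1cc(C(=O)O)ccc1CN1CCC[C@H](O[C@H](CO)c2cccc(Cl)c2)[C@@H]1c1ccccc1` is not yet measured. It differs from compound 1 in one place: 3-chlorophenyl in place of 2-chloropyridin-4-yl on a saturated chain carbon bound to an oxygen on a saturated carbon and a saturated chain carbon. The change sits on a saturated chain carbon bound to an oxygen on a saturated carbon and a saturated chain carbon; the 3-chlorophenyl that enters carries no hydrogen-bond acceptor, where the 2-chloropyridin-4-yl that leaves carried one.

With compound 1 at a limit and compound 3 at the same limit, the expectation for compound 4 is that it stays near that limit, so the step from compound 1 to compound 4 is estimated at a number no higher from compound 1 to compound 4 (the limit leaves the size open), none beyond the scatter in any clear direction. Compound 4 is expected to give about 200000 nM in this assay, within a range from 40000 nM to 600000 nM, most likely reported again only as a limit.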

Compound 4, half-maximal effective concentration: 93000 nM
For compound 4 the middle estimate is 2.2-fold (0.33 log units) above the measured one; measured number inside the range.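

In this assay, 3-chlorophenyl in place of 2-chloropyridin-4-yl on a saturated chain carbon bound to an oxygen on a saturated carbon and a saturated chain carbon gives an at least 2.1-fold lower number from compound 1 to compound 4 (0.33 log units; beyond the scatter). Among the compounds shown here, this shows what the earlier compounds could not: the group at this position affects the read-out, and replacing the ring nitrogen of the leaving group, its hydrogen-bond acceptor, with carbon is enough to give a measured number in place of a limit, though the full size of the step stays unknown. Compound 4 is the only compound shown with a number, while the others with a reported result remain at a limit: the limit of > 200000 nM in this assay, at which 2 of the 4 values shown sit.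

The compounds shown leave open whether the change in compound 4 depends on the loss of the ring nitrogen alone or also on the chlorine, and a fluorophenyl or methoxyphenyl group at this position would bear on that question. No other step can be read from these data, and whether the same change would act alike on a different core remains unanswered.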